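Chloro in place of fluoro on compound 2

The compounds below may be only part of what the source reports. "The series", "measured", "known", "first", "only" and "open" are said of these compounds alone.

In a functional assay on the whole organism with Mus musculus as the target, in the maximal electroshock model (on this read-out higher numbers stand for an effect only at larger amounts of compound and lower numbers for an effect already at smaller amounts), compound 1 `Nc1nnc(C(=O)N2CCCC2c2noc3cc(F)ccc23)c(N)n1` gives 7.1 mg/kg and compound 2 `Nc1nc(-c2ccccc2)nnc1C(=O)N1CCCC1c1noc2cc(F)ccc12` gives 6.2 mg/kg, so compound 2 stands level with compound 1, within the scatter. Compound 3 `Nc1nc(-c2ccccc2)nnc1C(=O)N1CCCC1c1noc2cc(Cl)ccc12` carries chloro in place of fluoro on an aromatic carbon. Within the data shown here, the only measured step, a 1.1-fold lower number from compound 1 to compound 2 (0.06 log units; within the scatter), is phenyl in place of amino, and no measured step involves fluoro or chloro. It offers only weak guidance, so no shift beyond the scatter is expected, in either direction. The estimated step is a 1.0-fold higher number from compound 2 to compound 3 (0.02 log units; within the scatter). Compound 3 is expected at 6.5 mg/kg, with a range of 3 mg/kg to 14 mg/kg.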

Compound 3, dose for half-maximal effect: 5.7 mg/kg
Estimate against measurement, compound 3: 1.1-fold (0.06 log units) above, within the range that was stated.
By their numbers in this assay, from the lowest: compounds 3, 2 and 1 (each within the scatter of the next).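

Chloro and fluoro on this aromatic carbon, meta to a fused ring and para to a fused ring, give a 1.1-fold lower number from compound 2 to compound 3 (0.04 log units; within the scatter) in this assay, so compound 2 and compound 3 stand level. Among these compounds, this is the first measured step at this place, and it shows that the read-out holds with either halogen there. No measurement on hand bears on this result.

Open, on these data alone, is whether a methoxy, a trifluoromethyl or an amine at this place would stay level with compound 3. Also open, as far as these compounds go, is whether chloro for fluoro reads the same on compound 1.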